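A Trimethylphenyl Swap on Compound 2

A few compounds are considered here, and "the series" means these few. Any claim that something is new, unique, unknown or untested is made for them only; others in the source may bear on it.

In a functional assay on Jurkat cells (Homo sapiens) for inhibition, read by CCK-8 assay, with a stated time of 48 h (on this read-out lower numbers stand for stronger inhibition of growth and higher numbers for weaker inhibition of growth), compound 1 `CN1CCN(c2ccc(Nc3ncc(Cl)c(NCc4ccco4)n3)nc2)CC1` gives > 100000 nM, which is a limit and not a true number. Going by the values given here, compound 2 `CCc1ccc(Nc2nc(Nc3ccc(N4CCN(C)CC4)cn3)ncc2Cl)cc1` gives 11100 nM, the only exact number so far. Compound 3 `Cc1cc(C)c(Nc2nc(Nc3ccc(N4CCN(C)CC4)cn3)ncc2Cl)c(C)c1` carries 2,4,6-trimethylphenyl in place of 4-ethylphenyl on a nitrogen on an aromatic ring. Among the compounds with values here, the only measured step at this place is an at least 9.0-fold lower number from compound 1 to compound 2 (0.95 log units; beyond the scatter), and it replaced a (furan-2-yl)methyl group, so it offers only a loose guide to this swap. No change beyond the scatter is expected, with the estimate leaning slightly weaker: a 1.4-fold higher number from compound 2 to compound 3 (0.16 log units; within the scatter). For compound 3 the estimated value is 16000 nM, with an expected range from 5000 nM to 60000 nM.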

Compound 3, concentration for 50% growth inhibition: 7600 nM
For compound 3 the middle estimate is 2.1-fold (0.32 log units) above the measured one, within the range that was stated.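

At this nitrogen, 2,4,6-trimethylphenyl and 4-ethylphenyl cannot be told apart in this assay: the swap gives a 1.5-fold lower number from compound 2 to compound 3 (0.16 log units; within the scatter). A second substituted phenyl group also stands clear of (furan-2-yl)methyl, with an at least 13-fold lower number from compound 1 to compound 3 (1.11 log units; beyond the scatter). That size is only a lower bound because compound 1 gives a limit: the limit of > 100000 nM in this assay, at which 1 of the 3 values shown sits.

Going by these compounds, whether a phenyl ring bearing an amine or a carboxylic acid would lower the number further stays open. A benzyl group here would help separate the effect of the ring type from that of the link to the nitrogen.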